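This account rests on a few compounds, and the source may have more. Where it says the series, first, only, none or still open, it means among the compounds named here.

Measured in an assay on isolated protein (Cavia porcellus) with Sigma non-opioid intracellular receptor 1 (Homo sapiens) as the target, read by radioligand binding; a higher number here means a weaker inhibitor, a lower number a stronger inhibitor:
compound 1 `O=c1cc(-c2ccccc2)oc2cccc(OCCCCCCCN3CCC(O)CC3)c12`, 65 nM
compound 2 `CN(C)CCCCCCCCCCOc1ccc2oc(-c3ccccc3)cc(=O)c2c1`, 341 nM
compound 3 `COc1cccc(-c2cc(=O)c3cc(OCCCCCCN4CCC(O)CC4)ccc3o2)c1`, 111 nM

Of these three numbers, compound 3 gives the second highest. Its nearest neighbour is compound 1, whose number is lower by an amount within the usual scatter, so the two cannot be told apart. Compound 2 sits furthest away, with a higher number, and that gap lies beyond the scatter.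

Compound 4 `O=c1cc(-c2ccncc2)oc2ccc(OCCCCCCN3CCC(O)CC3)cc12` has not yet been measured in this assay. It differs from compound 3 in one place: pyridin-4-yl in place of 3-methoxyphenyl on an aromatic carbon. Going by the values given here, no measured pair shows a change of this kind, so nothing here fixes its effect. The expectation for compound 4 is a step toward a weaker inhibitor, a 2.7-fold higher number from compound 3 to compound 4 (0.43 log units; beyond the scatter), somewhat beyond the scatter. Compound 4 is therefore estimated at 300 nM, with a range from 100 nM to 900 nM.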

Compound 4, half-maximal inhibitory concentration: 308 nM
The estimate for compound 4 lay 1.0-fold (0.01 log units) below the measured number; low and high end bracket the measured number.
By their numbers in this assay, from the lowest: compounds 1 and 3 (each within the scatter of the next); then compounds 4 and 2 (each within the scatter of the next).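

In this assay, replacing 3-methoxyphenyl with pyridin-4-yl on the aromatic carbon next to the ring oxygen gives a 2.8-fold higher number from compound 3 to compound 4 (0.44 log units; beyond the scatter). This shows that the number responds to the group at this position, since the rest of the molecule is unchanged. The swap removes the methoxy group and adds a ring nitrogen in a single step, so this pair cannot separate the two changes.

Going by these compounds, how a pyridin-3-yl or 4-methoxyphenyl group would compare remains open. Nothing available here explains the step.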